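Aryl exchange on a sulfonyl in a piperazine series

The compounds below may be only part of what the source reports. "The series", "measured", "known", "first", "only" and "open" are said of these compounds alone.

Compound 1 `COc1ccc(C(=O)N2CCN(c3nc(N)c4cc(OC)c(OC)cc4n3)CC2)cc1OC` gives 71000 nM in a functional assay on PC-3 cells (Homo sapiens) for inhibition; on this read-out higher numbers stand for weaker inhibition and lower numbers for stronger inhibition. Compound 2 `COc1cc2nc(N3CCN(C(=O)c4ccc(C(F)(F)F)cc4)CC3)nc(N)c2cc1OC` reaches only the limit of the assay, > 100000 nM. Compound 3 `COc1cc2nc(N3CCN(S(=O)(=O)c4ccc(Br)cc4)CC3)nc(N)c2cc1OC` gives 20000 nM.

Compound 3 stands lowest of the two numbers shown; compound 1 sits higher by a gap beyond the scatter, while compound 2 is a limit and not a number. Compound 4 `COc1cc2nc(N3CCN(S(=O)(=O)c4cccc([N+](=O)[O-])c4)CC3)nc(N)c2cc1OC` differs from compound 3 by 3-nitrophenyl in place of 4-bromophenyl on a sulfonyl sulfur. Among the measured compounds shown here, the only measured step, an at least 1.4-fold higher number from compound 1 to compound 2 (0.14 log units; that floor lies within the scatter), concerns an aryl exchange on a carbonyl carbon and ends at the limit (the limit of > 100000 nM in this assay, at which 1 of the 3 values shown sits); no step on a sulfonyl sulfur has been measured. Compound 4 is therefore expected to show no step beyond the scatter, no change at the digits printed from compound 3 to compound 4 (within the scatter). For compound 4 the estimate is 20000 nM, expected between 6000 nM and 65000 nM.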

Compound 4, half-maximal inhibitory concentration: 32000 nM
Beside the measured number, compound 4's estimate is 1.6-fold (0.20 log units) below it; the measured number falls inside the stated range.
By their numbers in this assay, from the lowest: compounds 3 and 4 (each within the scatter of the next); then compound 1. At a limit, above all of these: compound 2.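

The first step measured on a sulfonyl sulfur (a 1.6-fold higher number from compound 3 to compound 4 (0.20 log units; within the scatter)) shows that in this assay this position accepts 3-nitrophenyl in place of 4-bromophenyl with no difference beyond the scatter. Unlike the step on a carbonyl carbon, it ends at a number and not at a limit. Nothing measured here bears on why the two aryl groups read alike.

Still open, as far as these compounds go, is what a carboxylic acid or an amine on the phenyl ring would do. So is the effect of a longer alkyl chain in place of the aryl group on the sulfonyl sulfur.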